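Chain extension from compound 1: working notes

The source may report more compounds than this note shows. Statements on the series, on what has been measured and on what is new or still open speak of the compounds shown alone.

In a functional assay on NCI-H358 cells (Homo sapiens) for cytotoxicity, read by sulforhodamine B assay (on this read-out higher numbers stand for an effect only at larger amounts of compound and lower numbers for an effect already at smaller amounts), compound 1 (`CCCCCCCCCCCCCC[C@@H](O)[C@@H](O)[C@H](CO)n1cc(CCC)nn1`) gives 13200 nM and compound 2 (`CCCCCCCCCCCCC/C=C/[C@@H](O)[C@H](CO)n1cc(CCCCCC)nn1`) gives 12800 nM as its value. Within the data shown here, these two numbers lie within the scatter of each other, so compound 1 cannot be separated from the only other measured compound. Compound 3 (`CCCCCCCCCCCCCC[C@@H](O)[C@@H](O)[C@H](CO)n1cc(CCCCCCCCCCCCC)nn1`) follows from compound 1 with decyl in place of hydrogen on a saturated chain carbon, three bonds along the chain from an aromatic carbon. Among the measured compounds shown here, no step between measured compounds differing in one place is available to scale this change. In this assay a small shift toward a lower number is expected, possibly none beyond the scatter. The expected size of a 1.5-fold lower number from compound 1 to compound 3 (0.17 log units; within the scatter) is modest and uncertain. For compound 3 the estimate is 9000 nM with an expected range from 3000 nM to 30000 nM on repeated measurement.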

Compound 3, half-maximal effective concentration: > 50000 nM
Compound 3: only a limit was reported; the forecaster's own chance of this, stated with the estimate: 20%; at least 5.5-fold (0.74 log units) between middle value and limit.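

In this assay compound 3 gives > 50000 nM, which is a limit and not a number. Decyl in place of hydrogen on a saturated chain carbon, three bonds along the chain from an aromatic carbon, gives the first step that can be read at this position, and it runs upward: an at least 3.7-fold higher number from compound 1 to compound 3 (0.57 log units; beyond the scatter). This step fixes a direction and a smallest size for this one pair, while its full size stays unknown: the limit of > 50000 nM in this assay, at which 1 of the 3 values shown sits.

From the compounds shown here alone, whether a shorter group at this place, such as butyl or octyl, already moves the number remains open, as does the effect of an amine at the end of the decyl chain. Among these compounds, compound 2 differs from compound 1 in more than one place and therefore gives no second step for this change.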